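A few compounds are considered here, and "the series" means these few. Any claim that something is new, unique, unknown or untested is made for them only; others in the source may bear on it.

Compound 1 `Cc1ccc(-c2cnn3c(NCc4ccccn4)cc(C)nc23)cc1`: < 5000 nM
Compound 2 `Cc1cc(NCc2ccccn2)n2ncc(-c3ccccc3F)c2n1`: 5000 nM
Compound 3 `Cc1cc(NCc2ccccn2)n2ncc(-c3ccccc3C)c2n1`: < 5000 nM

In a physicochemical assay for solubility, read by HPLC, using the shake flask method, measured as kinetic solubility, with a stated time of 2 h, at pH 7.4 (on this read-out lower numbers stand for lower solubility and higher numbers for higher solubility), compound 1 reports only a limit, < 5000 nM. Compound 2 reports a number, 5000 nM. Compound 3 likewise reports only a limit, < 5000 nM. Compound 3 therefore stands at the limit of this assay (the limit of < 5000 nM in this assay, at which 2 of the 3 values shown sit), and none of the steps among the three is readable in size: a number no lower from compound 1 to compound 2 (the limit leaves the size open), a step that the two limits leave unreadable from compound 1 to compound 3, a number no higher from compound 2 to compound 3 (the limit leaves the size open).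

Compound 4 `Cc1cc(NCc2ccccn2)n2ncc(-c3ccn(C)n3)c2n1` differs from compound 3 in one place: 1-methyl-1H-pyrazol-3-yl in place of 2-methylphenyl on an aromatic carbon. Among the compounds with values here, no measured step exchanges a phenyl ring for a five-membered ring with two hetero atoms, so the measured steps give no guide to the size or direction of this change in this assay.

Compound 4 is expected to give about 9000 nM, within a range of 2000 nM to 40000 nM. The expected step is an at least 1.8-fold higher number from compound 3 to compound 4 (0.25 log units; that floor lies within the scatter).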

Compound 4, solubility: 188000 nM
For compound 4 the middle estimate is 21-fold (1.32 log units) below the measured one, and the stated range ends below it.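

In this assay, within the data shown here, the exchange of a substituted phenyl ring for 1-methyl-1H-pyrazol-3-yl at this aromatic carbon gives the first step of readable size: a 38-fold higher number from compound 2 to compound 4 (1.58 log units; beyond the scatter). The same exchange gives an at least 37-fold higher number from compound 3 to compound 4 (1.57 log units; beyond the scatter) and an at least 37-fold higher number from compound 1 to compound 4 (1.57 log units; beyond the scatter). Compound 1 and compound 3 each hold only a limit, so those two steps are floors: the limit of < 5000 nM in this assay, at which 2 of the 4 values shown sit.

From the compounds shown here alone, whether the ring nitrogens or the smaller ring goes with this step stays open, as the two change together here. Also open, going by these compounds, is how a pyridine ring or a morpholine at this carbon would read.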